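Swapping Benzylsulfanyl for Methylamino on a Nucleoside Core

A few compounds are considered here, and "the series" means these few. Any claim that something is new, unique, unknown or untested is made for them only; others in the source may bear on it.

Compound 1 `CCNc1nccc2c1ncn2C1O[C@H](CO)[C@@H](O)[C@H]1O` gives 4% in a functional assay (Homo sapiens) for inhibition of Nucleic Acid, tested at 100 uM; a higher number here means more inhibition at the concentration tested (going by the name of the read-out), a lower number less inhibition.
Compound 2 `OC[C@H]1OC(n2cnc3c(SCc4ccccc4)nccc32)[C@H](O)[C@@H]1O` gives 30% in this assay.
Compound 3 `OC[C@H]1O[C@@H](n2cnc3cnccc32)[C@H](O)[C@@H]1O` gives 13%; 1% (2 entries) in this assay.

Among the single numbers, compound 2 stands highest; its nearest neighbour is compound 1, and the step of a number 26 percentage points higher from compound 1 to compound 2 (beyond the scatter) sets it apart. The repeated entries of compound 3, (the several entries of compound 3 in this assay, 13%; 1% (2 entries)), show how much two measurements of the same compound can differ here.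

Compound 4 `CNc1nccc2c1ncn2C1O[C@H](CO)[C@@H](O)[C@H]1O` is the unmeasured partner of compound 2. It differs by methylamino in place of benzylsulfanyl on an aromatic carbon. Among the measured compounds shown here, only one measured step bears on this change: a number 26 percentage points higher from compound 1 to compound 2 (beyond the scatter), where the benzylsulfanyl group entered in place of a small alkylamino group. Compound 4 walks that step back, exchanging benzylsulfanyl for a small alkylamino group again, so a drop of a similar size is expected, landing near the level of compound 1. Compound 4 is therefore estimated at 5%, within 0% to 15%, the expected step being a number 25 percentage points lower from compound 2 to compound 4 (beyond the scatter).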

Compound 4, a percentage reported as inhibition, at one concentration (the size of the read-out at that concentration, not a potency): 8%
Compound 4: middle estimate off by 3 percentage points, on the low side, within the range that was stated.
By their numbers in this assay, from the lowest: compounds 1 and 4 (each within the scatter of the next); then compound 2.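

At this aromatic carbon, the higher reading of compound 2 now holds against a second small amino group as well as ethylamino (a number 22 percentage points lower from compound 2 to compound 4 (beyond the scatter)), so that comparison no longer rests on a single partner. The two amino compounds cannot be told apart, and the length of this short chain has no readable effect (a number 4 percentage points higher from compound 1 to compound 4 (within the scatter)). Even so, the step out of compound 2 should be read with care, since repeated readings of one compound can differ considerably in this read-out, as this example shows: the several entries of compound 3 in this assay, 13%; 1% (2 entries).

Still open, on these data alone, is whether the higher reading of compound 2 goes with its sulfur atom or with its six-membered aromatic ring of carbon. A benzylamino or a methylsulfanyl group on the same carbon would separate these two parts of the benzylsulfanyl group.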